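This account rests on a few compounds, and the source may have more. Where it says the series, first, only, none or still open, it means among the compounds named here.

Measured compounds so far:
- compound 1, `CCCCc1nc(C(C)C)c(CC(=O)OCC(F)(F)F)c(=O)n1Cc1ccc(-c2ccccc2-c2noc(=O)[nH]2)cc1`; "not determined" (no result reported) in an ADME assay on microsomes from liver (Homo sapiens) for metabolic stability, with a stated time of 30 min; a lower number here means that less of the compound is left, a higher number that more of the compound is left
- compound 2, `CCCCc1nc(C)c(CC(=O)OC)c(=O)n1Cc1ccc(-c2ccccc2-c2noc(=O)[nH]2)cc1`; 69.6%
- compound 3, `CCCCc1nc(C(C)(C)C)c(CC(=O)OCC)c(=O)n1Cc1ccc(-c2ccccc2-c2noc(=O)[nH]2)cc1`; 8.2%

Among the measured compounds shown here, compound 1 stands nowhere on the numbers: in this assay compound 1 gives "not determined" (no result reported), so its place can only be read from the two measured members that share its core. In this assay, for the measured compounds named here, compound 2 gives 69.6% and compound 3 gives 8.2%; the two values lie far apart, but the compounds differ in more than one place, so no single step between them can be drawn.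

Compound 4, `CCCCc1nc(C(C)C)c(C(C)C(=O)OCC)c(=O)n1Cc1ccc(-c2ccccc2-c2noc(=O)[nH]2)cc1`, differs from compound 1 in one place: 1-(ethoxycarbonyl)ethyl in place of ((2,2,2-trifluoroethoxy)carbonyl)methyl on an aromatic carbon

Going by the values given here, with no measured step for this change, no direction can be computed from the data; the size of any shift in this assay is therefore unknown, and the expectation for compound 4 rests on its position between compound 2 and compound 3. Compound 4 is expected to give about 30% in this assay, within a range of 10% to 60%.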

Compound 4, percent of the compound remaining: 11%
Compound 4: middle estimate off by 19 percentage points, on the high side; low and high end bracket the measured number.
By their numbers in this assay, from the lowest: compounds 3 and 4 (each within the scatter of the next); then compound 2.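

In this assay compound 1 gives "not determined" (no result reported), and compound 4 differs from compound 2 and compound 3 in more than one place, so no new step can be read. From the compounds shown here alone, the effect of replacing ((2,2,2-trifluoroethoxy)carbonyl)methyl with 1-(ethoxycarbonyl)ethyl on the percent remaining stays open. Nothing available explains the values seen.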